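Linear hydroxamate in place of aryl hydroxamate on triazole core

A few compounds are considered here, and "the series" means these few. Any claim that something is new, unique, unknown or untested is made for them only; others in the source may bear on it.

Measured compounds in an assay on Sf9 cells for inhibition of histone deacetylase 11 (Homo sapiens), read by fluorescence, tested at 0.5 uM; on this read-out higher numbers stand for more inhibition at the one concentration tested (going by the name of the read-out) and lower numbers for less inhibition:
compound 1, `O=C(NO)c1cccc(-c2cn([C@H]3C[C@@H](CO)N(CCCc4ccccc4)C3)nn2)c1`: < 10%
compound 2, `O=C(NO)c1cccc(-c2cn([C@H]3C[C@H](C(=O)O)N(CCCc4ccccc4)C3)nn2)c1`: < 10%
compound 3, `O=C(NO)c1cccc(-c2cn([C@H]3C[C@@H](C(=O)O)N(CCCc4ccccc4)C3)nn2)c1`: < 10%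

Compound 3 has the structure `O=C(NO)c1cccc(-c2cn([C@H]3C[C@@H](C(=O)O)N(CCCc4ccccc4)C3)nn2)c1` and in this assay gives < 10%, which is a limit of the assay rather than a number. Compound 1 also stops at a limit, < 10%. Compound 2 likewise gives only a limit, < 10%. The three measured values therefore tell nothing about the size of the steps between them: a step that the two limits leave unreadable from compound 1 to compound 3 cannot be read, and a step that the two limits leave unreadable from compound 2 to compound 3 cannot be read either, since (the limit of < 10% in this assay, at which 3 of the 3 values shown sit).

Compound 4, `O=C(/C=C/c1cn([C@H]2C[C@@H](C(=O)O)N(CCCc3ccccc3)C2)nn1)NO`, is not yet measured. It differs from compound 3 in one place: 2-(hydroxycarbamoyl)ethenyl in place of 3-(hydroxycarbamoyl)phenyl on an aromatic carbon. Going by the values given here, no measured step touches this part of the structure, so the size of the step from compound 3 to compound 4 has no counterpart in the data. Given that compound 3 sits at the limit, compound 4 is expected to stay in the same low region, with a step that the limit leaves unreadable from compound 3 to compound 4 as the estimated step. For compound 4 the estimated value in this assay is 8%, in the range from 0% to 25%.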

Compound 4, a percentage reported as inhibition, at one concentration (the size of the read-out at that concentration, not a potency): 29%
The estimate for compound 4 lay 21 percentage points below the measured number; measured number outside the range, above it.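

In this assay, this position on the five-membered aromatic ring responds to change: 2-(hydroxycarbamoyl)ethenyl in place of 3-(hydroxycarbamoyl)phenyl gives a number at least 19 percentage points higher from compound 3 to compound 4 (beyond the scatter). Both groups carry the same hydroxycarbamoyl unit, so the change lies in what joins that unit to the ring: a six-membered aromatic ring of carbon only in compound 3, and a chain with a double bond and no ring in compound 4. The earlier steps, which touched only the saturated ring carbon, cannot be read, and this step gives only a minimum size, not an exact one, because compound 3 has no number of its own: the limit of < 10% in this assay, at which 3 of the 4 values shown sit.

Going by these compounds alone, since only this one pair compares the two groups, it remains open whether the double bond matters or whether removing the aromatic ring is enough, and a saturated 2-(hydroxycarbamoyl)ethyl group or a longer chain would help to separate the two. As far as these compounds go, it also remains open whether the rise would carry over to the hydroxymethyl compounds, and a reading at one concentration gives no potency for compound 4.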